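Para-Phenyl Anilide: Expected Antiproliferative Potency of Compound 4

The compounds below may be only part of what the source reports. "The series", "measured", "known", "first", "only" and "open" are said of these compounds alone.

Compound 1 `O=C(CCc1cccc2c1B(O)OC2)Nc1ccccc1` has the lowest number of the three measured compounds: in a functional assay on MDA-MB-231 cells (Homo sapiens) for antiproliferative activity, read by MTT assay, with a stated time of 72 h (on this read-out lower numbers stand for stronger inhibition and higher numbers for weaker inhibition), compound 1 gives 230 nM, compound 2 `COc1ccccc1NC(=O)CCc1cccc2c1B(O)OC2` gives 930 nM and compound 3 `O=C(CCc1cccc2c1B(O)OC2)Nc1ccccc1-c1ccccc1` gives 18000 nM. Compound 4 `O=C(CCc1cccc2c1B(O)OC2)Nc1ccc(-c2ccccc2)cc1` differs from compound 1 by phenyl in place of hydrogen on an aromatic carbon. The measured steps that bear on it are a 4.0-fold higher number from compound 1 to compound 2 (0.61 log units; beyond the scatter) and a 78-fold higher number from compound 1 to compound 3 (1.89 log units; beyond the scatter), both of which weakened inhibition, the phenyl far more than the methoxy, and a 19-fold higher number from compound 2 to compound 3 (1.29 log units; beyond the scatter) points the same way. The phenyl of compound 4 enters at a different aromatic carbon, para to a large group, so the penalty seen in compound 3 need not carry over fully. Compound 4 is therefore expected to give 800 nM (range 200 nM to 4000 nM), a step of a 3.5-fold higher number from compound 1 to compound 4 (0.54 log units; beyond the scatter) expected toward weaker inhibition.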

Compound 4, half-maximal inhibitory concentration: 8800 nM
Estimate against measurement, compound 4: 11-fold (1.04 log units) below; the measured number lies above the stated range.
By their numbers in this assay, from the lowest: compound 1; then compound 2; then compound 4; then compound 3.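

In this assay, phenyl para to a large group also raises the number sharply, with a 38-fold higher number from compound 1 to compound 4 (1.58 log units; beyond the scatter), so the loss seen with phenyl in compound 3 is not confined to that one aromatic carbon. The anilide of compound 1 thus tolerates phenyl poorly at both carbons tested. Nothing measured here explains this loss.

The compounds shown leave open whether a smaller group at this same carbon, such as an amine or a carboxylic acid, would keep the number close to that of compound 1.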